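Fluoro to Chloro at the Para Position of a Thiophene Biaryl

The source may hold more compounds than are shown below. What is called first, only, known or untested is meant among the compounds shown, and "the series" means these compounds.

Measured compounds:
Compound 1, `N=C(N)c1ccc(-c2ccc(-c3cc(Cl)cc(Cl)c3)s2)cc1` — "not determined" (no result reported).
Compound 2, `N=C(N)c1ccc(-c2ccc(-c3ccc(F)cc3)s2)cc1` — 1560 nM.
Compound 3, `COc1cc(OC)cc(-c2ccc(-c3ccc(C(=N)N)cc3)s2)c1` — 2080 nM.

Three compounds share the amidine-bearing core; only the outer aryl ring differs. In a functional assay on MDA-MB-231 cells (Homo sapiens) for inhibition, read by sulforhodamine B assay, with a stated time of 48 h (on this read-out lower numbers stand for stronger inhibition of growth and higher numbers for weaker inhibition of growth), compound 2 gives 1560 nM. In this assay compound 3 gives 2080 nM, and the two numbers fall within the usual scatter of each other, so no order between compound 2 and compound 3 can be read from them. For compound 1 the entry in this assay reads "not determined" (no result reported).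

Compound 4, `N=C(N)c1ccc(-c2ccc(-c3ccc(Cl)cc3)s2)cc1`, is the next compound. It differs from compound 2 in one place: chloro in place of fluoro on an aromatic carbon. Among the measured compounds shown here, no measured pair of this kind exists in the set, so the size of this step is unknown. The expected step from compound 2 to compound 4 in this assay is a 1.3-fold lower number from compound 2 to compound 4 (0.11 log units; within the scatter), a small change that may not exceed the scatter. Compound 4 is expected to give about 1200 nM, in a range from 500 nM to 3000 nM.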

Compound 4, concentration for 50% growth inhibition: 184 nM
Beside the measured number, compound 4's estimate is 6.5-fold (0.81 log units) above it; the whole stated range lies above it.
By their numbers in this assay, from the lowest: compound 4; then compounds 2 and 3 (each within the scatter of the next).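

Chloro in place of fluoro, the change from 4-fluorophenyl to 4-chlorophenyl, gives an 8.5-fold lower number from compound 2 to compound 4 (0.93 log units; beyond the scatter) in this assay and is the only step that can be read in this set. The earlier numbers, for compound 2 and compound 3, lay within the scatter of each other and showed no order, whereas this result shows that the number responds strongly to the identity of the single halogen on this aromatic carbon. Among the compounds shown here, the step rests on one pair, so it describes only this exchange at this position and sets no trend across the halogens.

The compounds shown leave open whether bromo, methyl or an amine at the same position would continue this step or reverse it, and compound 1 gives no number for a second chloro. No measurement at hand accounts for the size of the step.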